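Changing the Group on the Ring Nitrogen of Compound 3

The source may report more compounds than this note shows. Statements on the series, on what has been measured and on what is new or still open speak of the compounds shown alone.

Of the compounds shown here, three sharing one core have been measured in a functional assay on MKN-74 cells (Homo sapiens) for antiproliferative activity, with a stated time of 24 h; a lower number here means a stronger inhibitor, a higher number a weaker inhibitor. Compound 1 `NC(=O)c1c(NC(=O)c2ccccc2Cl)sc2c1CCN(Cc1ccc(Cl)cc1)C2` gives 18700 nM, compound 2 `NC(=O)c1c(NC(=O)c2ccc(C(F)(F)F)cc2)sc2c1CCN(Cc1ccccc1F)C2` gives 26900 nM, and compound 3 `NC(=O)c1c(NC(=O)c2ccccc2Cl)sc2c1CCN(C(=O)Nc1ccccc1Cl)C2` gives 16300 nM. Compound 3 has the lowest of the three numbers, but its gaps to compound 1 and to compound 2 both lie inside the scatter of repeated measurements, so no order among the three can be read from them.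

Compound 4 `COc1ccc(NC(=S)N2CCc3c(sc(NC(=O)c4ccccc4Cl)c3C(N)=O)C2)cc1` has not yet been measured. It differs from compound 3 in one place: a group of 11 heavy atoms (8 carbon, 1 nitrogen, 1 oxygen, 1 sulfur; one six-membered aromatic ring of carbon only) in place of a group of 10 heavy atoms (7 carbon, 1 nitrogen, 1 oxygen, 1 chlorine; one six-membered aromatic ring of carbon only), on an amine nitrogen in a ring.

Within the data shown here, one measured step bears on this position. Replacing the 4-chlorobenzyl of compound 1 by the (2-chlorophenyl)carbamoyl of compound 3 gave a 1.1-fold lower number from compound 1 to compound 3 (0.06 log units; within the scatter), so an exchange of two rather different groups on this ring nitrogen left the number essentially where it was. The group entering in compound 4 again carries one six-membered aromatic ring of carbon only and one hydrogen-bond donor, so the same outcome seems most likely. Compound 4 is therefore expected to show no step beyond the scatter, a 1.0-fold lower number from compound 3 to compound 4 (0.01 log units; within the scatter). The estimate for compound 4 is 16000 nM, with a range from 7000 nM to 36000 nM; a single comparison cannot rule out a larger step in either direction.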

Compound 4, half-maximal inhibitory concentration: 19600 nM
Compound 4: the middle estimate sits 1.2-fold (0.09 log units) below what was measured; the measured number falls inside the stated range.
By their numbers in this assay, from the lowest: compounds 3, 1, 4 and 2 (each within the scatter of the next).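

In this assay the group entering in compound 4, which holds sulfur and no chlorine, gives a 1.2-fold higher number from compound 3 to compound 4 (0.08 log units; within the scatter) and a 1.0-fold higher number from compound 1 to compound 4 (0.02 log units; within the scatter) as its two new steps. The earlier compounds shown here offered a single comparison on this amine nitrogen in a ring, whereas three different groups on the same core can now be compared, and compound 1, compound 3 and compound 4 all lie within the scatter of one another. Each of these groups carries one six-membered aromatic ring of carbon only, and no outside measurement is available to explain why the numbers stay so close.

The group in compound 4 differs from that in compound 3 in more than one feature, holding sulfur and a methoxy group where compound 3 has oxygen and chlorine, so the compounds shown cannot separate what each feature contributes. From the compounds shown here alone, it also remains open whether a group without an aromatic ring on this nitrogen, such as a plain methyl or a short chain ending in an amine, would give a number beyond the scatter.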